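Methyl on the Amide Nitrogen: What to Expect

The source may report more compounds than this note shows. Statements on the series, on what has been measured and on what is new or still open speak of the compounds shown alone.

Measured compounds:
compound 1 `COc1ccc(CN2CCC(C(=O)NCC3(c4ccc(F)cc4)CCCCC3)CC2)cc1OC`: 320 nM
compound 2 `O=C(NCC1(c2ccc(F)cc2)CCCCC1)C1CCN(Cc2ccccc2)CC1`: 510 nM
compound 3 `O=C(NCC1(c2ccc(F)cc2)CCCC1)C1CCN(Cc2ccccc2)CC1`: 220 nM

In an assay on HEK293 cells for inhibition of Voltage-dependent T-type calcium channel subunit alpha-1G (Homo sapiens), read by FLIPR and calcium flux (a lower number here means a stronger inhibitor, a higher number a weaker inhibitor), compound 2 gives 510 nM, the highest of the three numbers. Its nearest neighbour is compound 1, reached by the step of a 1.6-fold higher number from compound 1 to compound 2 (0.20 log units; within the scatter), so these two cannot be told apart. Compound 3, with 220 nM, has the lowest of the three numbers, and its gap to compound 2 lies beyond the usual scatter.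

Compound 4 `CN(CC1(c2ccc(F)cc2)CCCCC1)C(=O)C1CCN(Cc2ccccc2)CC1` differs from compound 2 by methyl in place of hydrogen on an amide-type nitrogen. Within the data shown here, none of the measured compounds tests a change at this position: the one measured step alters the group on the saturated chain carbon bound to the ring amine nitrogen, a different part of the molecule, and it was within the scatter. There is thus no direct guide for the effect of removing the amide hydrogen, and the expectation must stay broad. Compound 4 is expected to give about 700 nM in this assay, with a range from 250 nM to 2500 nM. This amounts to an expected step of a 1.4-fold higher number from compound 2 to compound 4 (0.14 log units; within the scatter), with the direction uncertain.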

Compound 4, half-maximal inhibitory concentration: 750 nM
Estimate against measurement, compound 4: 1.1-fold (0.03 log units) below; measured number inside the range.
By their numbers in this assay, from the lowest: compounds 3, 1, 2 and 4 (each within the scatter of the next, the first and the last beyond it).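

Placing methyl on the amide-type nitrogen, the only change at this position among the compounds shown, gives a 1.5-fold higher number from compound 2 to compound 4 (0.17 log units; within the scatter) in this assay, so this pair cannot be told apart. The earlier compounds shown here said nothing about this nitrogen, whereas this pair shows that, on the core of compound 2, a compound without the amide hydrogen still inhibits the channel at a level indistinguishable from that of the compound that keeps it, though a single pair cannot show a general rule. No separate measurement bears on why the two compounds read so alike, so the result describes an outcome and gives no explanation.

Going by these compounds, a single methyl is a small replacement, so it remains open how a longer chain such as n-butyl, or a benzyl group, would read on this same nitrogen. On these data alone, it is also open whether methyl gives a similar outcome on the core of compound 3, which gives 220 nM with the amide hydrogen in place.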